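Sulfonyl substituent variation in a squalene monooxygenase inhibitor series

This account rests on a few compounds, and the source may have more. Where it says the series, first, only, none or still open, it means among the compounds named here.

Measured so far in a functional assay on HepG2 cells for inhibition of squalene monooxygenase (Homo sapiens); a lower number here means a stronger inhibitor, a higher number a weaker inhibitor:
compound 1 `CCN(C/C=C/C#CC(C)(C)C)Cc1cccc(OCCN(C)S(=O)(=O)c2ccc(F)cc2)c1`, compound 1 gives 255 nM
compound 2 `CCN(C/C=C/C#CC(C)(C)C)Cc1cccc(OCCN(C)S(=O)(=O)Cc2cccs2)c1`, compound 2 gives 200 nM

Among the measured compounds shown here, compound 2 holds the lower of the two numbers in this assay, but its only neighbour is compound 1, and the step of a 1.3-fold lower number from compound 1 to compound 2 (0.11 log units; within the scatter) lies within the scatter, so the two are not separable. Compound 3 `CCN(C/C=C/C#CC(C)(C)C)Cc1cccc(OCCN(C)S(=O)(=O)c2cc(Br)cs2)c1` is the next member; it differs from compound 2 by 4-bromothiophen-2-yl in place of (thiophen-2-yl)methyl on a sulfonyl sulfur. For the measured compounds named here, the only measured step that bears on this position is a 1.3-fold lower number from compound 1 to compound 2 (0.11 log units; within the scatter), which exchanged one group on the same sulfonyl sulfur for another without a change beyond the scatter. A further exchange at the same place is therefore expected to leave this assay essentially unchanged, an expected step of a 1.1-fold higher number from compound 2 to compound 3 (0.04 log units; within the scatter). For compound 3 the estimate in this assay is 220 nM, within an expected range of 100 nM to 500 nM.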

Compound 3, half-maximal inhibitory concentration: 300 nM
The estimate for compound 3 lay 1.4-fold (0.13 log units) below the measured number, and the stated range covers the measured number.
By their numbers in this assay, from the lowest: compounds 2, 1 and 3 (each within the scatter of the next).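

In this assay, the step of a 1.5-fold higher number from compound 2 to compound 3 (0.18 log units; within the scatter) and the step of a 1.2-fold higher number from compound 1 to compound 3 (0.07 log units; within the scatter) both lie within the scatter, so all three compounds remain inseparable. On this sulfonyl sulfur, 4-bromothiophen-2-yl therefore reads the same as both (thiophen-2-yl)methyl and 4-fluorophenyl, and neither the bromine nor the change from the methyl-linked thiophene to a ring bound directly to sulfur produces a change beyond the scatter. No measurement is available that would explain this flat response.

All three groups shown carry an aromatic ring, so it remains open whether an amine, a carboxylic acid or a longer alkyl chain on the same sulfur would also stay within the scatter. The effect of the bromine alone also remains open, as plain thiophen-2-yl does not appear among these compounds.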